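The source may hold more compounds than are shown below. What is called first, only, known or untested is meant among the compounds shown, and "the series" means these compounds.

Measured compounds:
compound 1 `Cn1cnc(CN2CCN(c3cccc4[nH]c(-c5ccc(C(C)(C)C)cc5)nc34)CC2)c1`; in an assay on isolated protein for displacement of a labelled ligand from Gonadotropin-releasing hormone receptor (Rattus norvegicus) (on this read-out lower numbers stand for stronger inhibition and higher numbers for weaker inhibition), compound 1 gives 98 nM
compound 2 `CCc1nc(C)c(CN2CCN(c3cccc4[nH]c(-c5ccc(C(C)(C)C)cc5)nc34)CC2)o1`; in this assay compound 2 gives 320 nM

Among the compounds with values here, compound 2 holds the higher of the two numbers measured so far, since the step of a 3.3-fold higher number from compound 1 to compound 2 (0.51 log units; beyond the scatter) lies beyond the scatter. Compound 3 `CCc1nc(C)c(CN2CCN(c3cccc4[nH]c(-c5ccc(C(C)(C)C)cc5)nc34)CC2)s1` differs from compound 2 in one place: 2-ethyl-4-methyl-1,3-thiazol-5-yl in place of 2-ethyl-4-methyl-1,3-oxazol-5-yl on a saturated chain carbon bound to an amine nitrogen in a ring. Within the data shown here, no measured step covers an exchange of oxygen for sulfur in such a ring. Among the measured compounds shown here, the only step measured at the same saturated chain carbon bound to an amine nitrogen in a ring, a 3.3-fold higher number from compound 1 to compound 2 (0.51 log units; beyond the scatter), concerns a different five-membered heteroaryl group and was modest, so it offers only weak guidance. The expected step of a 1.3-fold lower number from compound 2 to compound 3 (0.11 log units; within the scatter) is therefore none beyond the scatter, with the number for compound 3 estimated close to that of compound 2. Compound 3 is estimated at 250 nM in this assay, with a range from 80 nM to 800 nM.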

Compound 3, half-maximal inhibitory concentration: 120 nM
Compound 3: the middle estimate sits 2.1-fold (0.32 log units) above what was measured, and the stated range covers the measured number.
By their numbers in this assay, from the lowest: compounds 1 and 3 (each within the scatter of the next); then compound 2.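

In this assay, exchanging the ring oxygen of 2-ethyl-4-methyl-1,3-oxazol-5-yl for the sulfur of 2-ethyl-4-methyl-1,3-thiazol-5-yl, with the ethyl and methyl groups kept, gives a 2.7-fold lower number from compound 2 to compound 3 (0.43 log units; beyond the scatter), so a single ring atom matters at this place on the saturated chain carbon. Set against 1-methyl-1H-imidazol-4-yl, the same group gives a 1.2-fold higher number from compound 1 to compound 3 (0.09 log units; within the scatter), so these two different five-membered rings cannot be told apart here. Nothing available explains why the oxygen and sulfur rings differ.

From the compounds shown here alone, whether the exchange of oxygen for sulfur would give a similar step with other groups on the ring, such as a 1,3-thiazol-5-yl without the ethyl and methyl groups, stays open. So does how a phenyl or pyridine ring, or a longer chain at this place, would compare.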